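The source may hold more compounds than are shown below. What is called first, only, known or untested is meant among the compounds shown, and "the series" means these compounds.

Two compounds of the series carry numbers in a toxicity assay on L02 cells (Homo sapiens) for cytotoxicity; a lower number here means a stronger inhibitor, a higher number a weaker inhibitor. Compound 1 `CC(C)(C)OC(=O)/C=C1/C(=O)Nc2ccccc21` gives 6210 nM in this assay. Compound 2 `CN1C(=O)/C(=C/C(=O)OC(C)(C)C)c2ccccc21` gives 12200 nM in this assay. For the measured compounds named here, the single measured step, a 2.0-fold higher number from compound 1 to compound 2 (0.29 log units; within the scatter), concerns methyl in place of hydrogen on an amide-type nitrogen in a ring and stays within the scatter, so compound 1 and compound 2 cannot be placed one above the other on these numbers.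

Compound 3 `CC(C)(C)OC(=O)/C=C1/C(=O)Nc2ccc(Cl)cc21` has not yet been run in this assay. It differs from compound 1 by chloro in place of hydrogen on an aromatic carbon. Going by the values given here, no measured step touches the carbon ring of the shared core, and the one step known in this assay lies within the scatter, so nothing here points to a shift beyond the scatter in either direction. The expected step is a 1.0-fold lower number from compound 1 to compound 3 (0.01 log units; within the scatter). The estimate for compound 3 in this assay is 6000 nM, with a range from 2500 nM to 15000 nM.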

Compound 3, half-maximal inhibitory concentration: 6180 nM
The estimate for compound 3 lay 1.0-fold (0.01 log units) below the measured number; low and high end bracket the measured number.
By their numbers in this assay, from the lowest: compounds 3, 1 and 2 (each within the scatter of the next).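

Chloro in place of hydrogen on an aromatic carbon is the first measured change on the carbon ring of the shared core, and in this assay it gives a 1.0-fold lower number from compound 1 to compound 3 (0.00 log units; within the scatter) with no separation between the two compounds. At this one position, meta to a fused ring and para to a fused ring, the chloro group is therefore accepted without a readable shift, whereas the earlier step spoke only to the amide-type nitrogen. No measured evidence bears on this result.

On these data alone, whether an amine, a methoxy group or a carboxylic acid at this position would reach beyond the scatter stays open. Also open, as far as these compounds go, is whether chloro on another aromatic carbon, or chloro combined with methyl on the amide-type nitrogen, would read the same.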